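The compounds below may be only part of what the source reports. "The series", "measured", "known", "first", "only" and "open" are said of these compounds alone.

Measured in a functional assay on HepG2 cells (Homo sapiens) for antiproliferative activity, read by CCK-8 assay, with a stated time of 72 h, tested at 2 uM; on this read-out higher numbers stand for a stronger effect at the one concentration tested and lower numbers for a weaker effect:
Compound 1, `Nc1ccccc1NC(=O)/C=C/c1ccc(Cn2cnc3c(NCc4ccccc4)nc(Cl)nc32)cc1`: 11.5%
Compound 2, `Nc1ccccc1NC(=O)c1ccc(Cn2cnc3c(Nc4ccc(-c5ccccn5)cc4)nc(Cl)nc32)cc1`: 11.5%
Compound 3, `COC(CCn1cnc2c(NCc3ccc(C(=O)Nc4ccccc4N)cc3)nc(Cl)nc21)OC`: 8.52%

Going by the values given here, compound 3 stands within the scatter of both compound 1 and compound 2 in this assay; none of the three numbers is separated from the others, and no step between measured compounds differing in one place is available in this set. Compound 4, `CCCCn1cnc2c(NCc3ccc(C(=O)Nc4ccccc4N)cc3)nc(Cl)nc21`, differs from compound 3 by ethyl in place of dimethoxymethyl on a saturated chain carbon, two bonds along the chain from an aromatic nitrogen. With no comparable change measured, the basis for expecting a shift is thin, and all three measured compounds give small inhibition at the single concentration tested. For compound 4 the step is expected to be a number 0.5 percentage points higher from compound 3 to compound 4 (within the scatter), nothing beyond the scatter in either direction. Compound 4 is estimated at 9%, in the range 0% to 22%.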

Compound 4, a percentage reported as inhibition, at one concentration (the size of the read-out at that concentration, not a potency): 6.8%
The estimate for compound 4 lay 2.2 percentage points above the measured number; low and high end bracket the measured number.
By their numbers in this assay, from the lowest: compounds 4, 3, 1 and 2 (each within the scatter of the next).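

In this assay, going by these compounds alone, the first one-place step reads a number 1.7 percentage points lower from compound 3 to compound 4 (within the scatter) with ethyl in place of dimethoxymethyl on a saturated chain carbon, two bonds along the chain from an aromatic nitrogen. At this position, removing both oxygen atoms of the dimethoxymethyl group therefore gives no separable change, though this single step sits among small numbers and shows no more than that. Nothing available bears on why the number stays put.

On these data alone, whether an amine, a carboxylic acid or a longer chain at this place would move the inhibition beyond the scatter remains open. So does whether any change here matters more than changes elsewhere on the shared core.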